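Chloromethylbenzyl purines: amino for chloro at compound 1

The source may report more compounds than this note shows. Statements on the series, on what has been measured and on what is new or still open speak of the compounds shown alone.

Measured so far in a functional assay on U-251 cells (Homo sapiens) for cytotoxicity, read by sulforhodamine B assay, with a stated time of 48 h; on this read-out lower numbers stand for stronger inhibition of growth and higher numbers for weaker inhibition of growth:
compound 1 `ClCc1ccccc1Cn1cnc2c(Cl)nc(Cl)nc21`: 1020 nM
compound 2 `ClCc1ccccc1Cn1cnc2ncnc(Cl)c21`: 4360 nM
compound 3 `ClCc1ccc(Cn2cnc3c(Cl)nc(Cl)nc32)cc1`: 3890 nM

Compound 1 stands at the lowest number of the three in this assay; compound 3 lies beyond the scatter above it and compound 2 further still, so compound 1 is the strongest of the measured set on this read-out. Compound 2 and compound 3 are within the scatter of each other, and nothing is said here about their order.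

Compound 4 `Nc1nc(Cl)c2ncn(Cc3ccccc3CCl)c2n1` is not yet measured. It differs from compound 1 in one place: amino in place of chloro on an aromatic carbon. Going by the values given here, no measured pair carries this exact change, so the size of the step from compound 1 to compound 4 cannot be read from the numbers; it is a matter of expectation only. The two measured departures from compound 1, in compound 2 and compound 3, both run toward higher numbers, and a modest rise beyond the scatter is the working expectation here, with a real chance that it stays within the scatter.

The expected step is a 2.5-fold higher number from compound 1 to compound 4 (0.39 log units; beyond the scatter). Compound 4 is estimated at 2500 nM, with a range from 800 nM to 8000 nM.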

Compound 4, concentration for total growth inhibition: 13500 nM
Beside the measured number, compound 4's estimate is 5.4-fold (0.73 log units) below it, and the stated range ends below it.
By their numbers in this assay, from the lowest: compound 1; then compounds 3 and 2 (each within the scatter of the next); then compound 4.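

In this assay, going by these compounds alone, the chloro on the aromatic carbon between two ring nitrogen atoms gives the first single-place change that can be read: amino in place of chloro there brings a 13-fold higher number from compound 1 to compound 4 (1.12 log units; beyond the scatter). The step is large and beyond the scatter, and the rest of the structure stays the same, including the second chloro group and the chloromethylbenzyl unit, so this one place is sensitive to this exchange on this read-out. The earlier compounds could not show this, as none of them forms a single-place pair, and nothing given here explains the size of the step.

As far as these compounds go, it remains open whether the rise belongs to amino itself or to the loss of chloro, a question that a methylamino, methoxy or fluoro group at this place would help to settle. It is also unknown whether the same exchange carries a similar step at the other chloro group of compound 1, or in compound 3, where the chloromethyl group stands elsewhere on the benzyl ring.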